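Swapping a methoxymethyl side chain for a fluoromethyl chain

The source may hold more compounds than are shown below. What is called first, only, known or untested is meant among the compounds shown, and "the series" means these compounds.

For the measured compounds named here, compound 1 `COC[C@@H](C(C)C)C(c1ccc(O)c(OC)c1)c1ccc(O)c(OC)c1` holds the only numerical value in this set: in a functional assay on HeLa cells (Homo sapiens) for cytotoxicity, read by WST assay, with a stated time of 48 h (a higher number here means a weaker inhibitor, a lower number a stronger inhibitor), compound 1 gives 69000 nM. Compound 2 `COc1ccc(C(c2ccc(OC)c(OC)c2)[C@@H](C)[C@@H](C)CO)cc1OC` is reported only as a limit of this assay, > 100000 nM. That reading is the limit of > 100000 nM in this assay, at which 1 of the 2 values shown sits. Compound 3 `COc1cc(C(c2ccc(O)c(OC)c2)[C@H](C)[C@@H](C)CF)ccc1O` differs from compound 1 by 2-(fluoromethyl)-1-methylpropyl in place of 1-(methoxymethyl)-2-methylpropyl on a saturated chain carbon bound to two aromatic carbons. Going by the values given here, no step between two measured compounds is available to calibrate this change, so the step from compound 1 to compound 3 is expected to stay within the usual scatter, a 1.1-fold lower number from compound 1 to compound 3 (0.03 log units; within the scatter). Compound 3 is therefore estimated at 65000 nM, with a range from 25000 nM to 100000 nM.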

Compound 3, half-maximal inhibitory concentration: 34000 nM
For compound 3 the middle estimate is 1.9-fold (0.28 log units) above the measured one; measured number inside the range.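

In this assay, for the compounds shown here, the exchange on the saturated chain carbon bound to two aromatic carbons gives a 2.0-fold lower number from compound 1 to compound 3 (0.31 log units; beyond the scatter), a modest step and the first measured change at this position. It shows that this position accepts 2-(fluoromethyl)-1-methylpropyl in place of 1-(methoxymethyl)-2-methylpropyl, and that in this pair losing the methoxymethyl oxygen does not weaken the compound. Nothing measured here accounts for the step.

Going by these compounds, whether the fluorine or the altered branching carries the step stays open. So does what a longer chain, an amine or a hydroxymethyl group would give at this place.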